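Bromo in Place of Hydrogen on Compound 2

The compounds below may be only part of what the source reports. "The series", "measured", "known", "first", "only" and "open" are said of these compounds alone.

Compound 1 `COc1ccccc1/C=c1\c(=O)[nH]/c(=C/c2cccc(Cl)c2Cl)c(=O)n1C` and compound 2 `C=CCn1c(=O)/c(=C\c2ccccc2F)[nH]c(=O)/c1=C\c1ccccc1OC` share the same core. Going by the values given here, in a functional assay on Huh-7 cells (Homo sapiens) for cytotoxicity, read by CCK-8 assay, with a stated time of 72 h (a lower number here means a stronger inhibitor, a higher number a weaker inhibitor), compound 1 gives 300 nM, while compound 2 gives 31300 nM, the higher of the two numbers and beyond the scatter from compound 1; the two differ in more than one place, so no single step is read from them. Compound 3 `C=CCn1c(=O)/c(=C\c2cc(Br)ccc2F)[nH]c(=O)/c1=C\c1ccccc1OC` carries bromo in place of hydrogen on an aromatic carbon. Among the compounds with values here, no measured pair shows this change, so the step is expected to stay modest and of uncertain direction, a 1.6-fold lower number from compound 2 to compound 3 (0.19 log units; within the scatter). Compound 3 is expected near 20000 nM, between 5000 nM and 80000 nM.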

Compound 3, half-maximal inhibitory concentration: "not active" (no number reported)
Compound 3: no number reported; the estimate stays without a comparison.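

In this assay, going by these compounds alone, compound 3 is reported as not active without a number, so no step from compound 2 to compound 3 can be read. The effect of bromo on this number stays open, and no measurement shown bears on a cause.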